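A Chloro Substituent on a Chalcone Without a Measured Anchor

This account rests on a few compounds, and the source may have more. Where it says the series, first, only, none or still open, it means among the compounds named here.

Three related chalcones have been tested in a functional assay on HT-29 cells (Homo sapiens) for antiproliferative activity, read by MTT assay, with a stated time of 24 h; a higher number here means a weaker inhibitor, a lower number a stronger inhibitor. Compound 1 `COc1ccc(C(=O)/C=C/c2ccc(-c3ccccc3)cc2)c2c1C=CC(C)(C)O2` reports only a limit, > 10000 nM. Compound 3 `COc1ccc(C(=O)/C=C/c2ccccc2)c2c1C=CC(C)(C)O2` likewise reports only a limit, > 10000 nM. Compound 2 `CCN(CC)c1ccc(/C=C/C(=O)c2ccc(OC)c3c2OC(C)(C)C=C3)cc1` gives 550 nM. The steps between them show an at least 18-fold lower number from compound 1 to compound 2 (1.25 log units; beyond the scatter) and an at least 18-fold higher number from compound 2 to compound 3 (1.25 log units; beyond the scatter), while a step that the two limits leave unreadable from compound 1 to compound 3; this is because of the limit of > 10000 nM in this assay, at which 2 of the 3 values shown sit. Compound 3 thus stands at the upper edge of what this assay reports, together with one other measured value.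

Compound 4 `COc1ccc(C(=O)/C=C/c2ccccc2Cl)c2c1C=CC(C)(C)O2` differs from compound 3 by chloro in place of hydrogen on an aromatic carbon. Within the data shown here, no measured step involves a chloro group, and the only steps that read as large both concern a diethylamino group, so none bears directly on this change. A change of this kind on a compound that already sits at the limit gives little reason to expect a reading below it. In this assay compound 4 is therefore expected to give 10000 nM, with a likely range from 3000 nM to 30000 nM. The expected step is a number no higher from compound 3 to compound 4 (the limit leaves the size open), meaning no change beyond the scatter.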

Compound 4, half-maximal inhibitory concentration: > 10000 nM
Compound 4: a limit, no number; the forecaster's own chance of this, stated with the estimate: 70%; the middle value sits exactly at the limit.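

No step from compound 3 to compound 4 can be read, because both compounds report only a limit: the limit of > 10000 nM in this assay, at which 3 of the 4 values shown sit.

The compounds shown leave open what chloro in place of hydrogen does to the number in this assay when the starting compound has a measured value rather than a limit.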